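Changing the aryl group from compound 2 to compound 3

A few compounds are considered here, and "the series" means these few. Any claim that something is new, unique, unknown or untested is made for them only; others in the source may bear on it.

Measured in a functional assay on RT-112 cells (Homo sapiens) for antiproliferative activity, read by MTT assay, with a stated time of 72 h; on this read-out higher numbers stand for weaker inhibition of growth and lower numbers for stronger inhibition of growth:
compound 1 `COc1cc(Nc2ncnc3c(NC(=O)Nc4cccc(C)c4C)cccc23)cc(OC)c1`, 5910 nM
compound 2 `COc1cc(Nc2ncnc3c(NC(=O)Nc4ccc(F)cc4F)cccc23)cc(OC)c1`, 2460 nM

Compound 2 holds the lower of the two numbers, which makes it the stronger growth inhibitor of the pair in this assay. Next comes compound 3 `CCOC(=O)c1ccc(NC(=O)Nc2cccc3c(Nc4cc(OC)cc(OC)c4)ncnc23)cc1`, with the change 4-(ethoxycarbonyl)phenyl in place of 2,4-difluorophenyl on an amide-type nitrogen, with the shared core untouched. Within the data shown here, one measured step bears on it, at the same place: a 2.4-fold lower number from compound 1 to compound 2 (0.38 log units; beyond the scatter). Among the measured compounds shown here, a single step gives no trend, and no measured compound carries the ethoxycarbonyl group. A step of similar modest size is therefore expected, leaning towards a higher number, since compound 2 at 2460 nM is the lower end so far. The expected shift is a 1.3-fold higher number from compound 2 to compound 3 (0.11 log units; within the scatter). For compound 3 the estimate is 3200 nM, with an expected range from 1100 nM to 9000 nM.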

Compound 3, concentration for 50% growth inhibition: 317 nM
Compound 3: the middle estimate sits 10-fold (1.00 log units) above what was measured; the measured number lies below the stated range.
By their numbers in this assay, from the lowest: compound 3; then compound 2; then compound 1.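

In this assay, the aryl group on the amide-type nitrogen has more influence than the first pair showed: 4-(ethoxycarbonyl)phenyl in place of 2,4-difluorophenyl gives a 7.8-fold lower number from compound 2 to compound 3 (0.89 log units; beyond the scatter). Against 2,3-dimethylphenyl, the same group gives a 19-fold lower number from compound 1 to compound 3 (1.27 log units; beyond the scatter), which leaves compound 3 with the lowest number of the three and shows that this position tolerates a larger aryl group carrying an ester. No available measurement accounts for this gain.

Among these compounds, compound 3 is the only compound here with an ester, so it remains open whether the gain belongs to the ethoxycarbonyl group itself or would persist with a carboxylic acid, a primary amide or a longer ester chain. Going by these compounds, the shared core stays the same throughout, so the contribution of its other substituents also remains open.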